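The compounds below may be only part of what the source reports. "The series", "measured", "known", "first", "only" and "open" are said of these compounds alone.

Measured so far in a functional assay on HT-29 cells (Homo sapiens) for cytotoxicity, read by MTT assay, with a stated time of 72 h; on this read-out lower numbers stand for stronger inhibition and higher numbers for weaker inhibition:

- compound 1, `COc1cc2c(Oc3ccc(NC(=O)c4cc(-c5ccc(C)cc5)ccn4)cc3F)ccnc2cc1OCCCN1CCCC1`: 350 nM
- compound 2, `COc1cc2c(Oc3ccc(NC(=O)c4cc(-c5ccccc5C)ccn4)cc3F)ccnc2cc1OCCCN1CCCC1`: 1150 nM

For the measured compounds named here, compound 2 stands at the highest of the two numbers recorded in this assay, compound 1 being the only neighbour and sitting at a lower number. Going by the values given here, the one step measured within the pair, a 3.3-fold higher number from compound 1 to compound 2 (0.52 log units; beyond the scatter), is the only comparison that bears on the next change.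

Compound 3, `COc1cc2c(Oc3ccc(NC(=O)c4cc(-c5ccc(C(F)(F)F)cc5)ccn4)cc3F)ccnc2cc1OCCCN1CCCC1`, differs from compound 2 by 4-(trifluoromethyl)phenyl in place of 2-methylphenyl on an aromatic carbon. The measured step ran from 4-methylphenyl to 2-methylphenyl; compound 3 returns to a group substituted in the 4-position of the phenyl, now with trifluoromethyl instead of methyl. Because compound 1 with its 4-methylphenyl gives 350 nM, compound 3 is expected to land near that number rather than near compound 2, which means an estimated step of a 2.9-fold lower number from compound 2 to compound 3 (0.46 log units; beyond the scatter). The estimate for compound 3 in this assay is 400 nM, with a range of 150 nM to 1100 nM.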

Compound 3, half-maximal inhibitory concentration: 720 nM
For compound 3 the middle estimate is 1.8-fold (0.26 log units) below the measured one; the measured number falls inside the stated range.
By their numbers in this assay, from the lowest: compound 1; then compounds 3 and 2 (each within the scatter of the next).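

In this assay, trifluoromethyl in place of methyl on the phenyl gives a 2.1-fold higher number from compound 1 to compound 3 (0.31 log units; beyond the scatter), so the 4-methylphenyl group of compound 1 cannot be exchanged at this place without a modest loss, even when the new group keeps the same substitution position. The other step, a 1.6-fold lower number from compound 2 to compound 3 (0.20 log units; within the scatter), lies within the scatter, so 4-(trifluoromethyl)phenyl and 2-methylphenyl cannot be told apart here, and compound 1 alone stands apart from the other two. Nothing available bears on why these numbers differ.

As far as these compounds go, it remains open whether unsubstituted phenyl would group with compound 1 or with compounds 2 and 3. Also open, from the compounds shown here alone, is how a methoxy group, a chlorine atom or a dimethylamino group on this phenyl would compare with methyl.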